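Amine side chain of the series: ethylamino to dimethylamino

The compounds below may be only part of what the source reports. "The series", "measured", "known", "first", "only" and "open" are said of these compounds alone.

Measured compounds in a functional assay on A549 cells (Homo sapiens) for antiproliferative activity, read by MTT assay, with a stated time of 48 h (a lower number here means a stronger inhibitor, a higher number a weaker inhibitor), are:
- compound 1 `CNCC(=O)Nc1cc(OC)ccc1C(=O)c1ccc(OC)c2c1C=CC(C)(C)O2` gives 1370 nM
- compound 2 `CCNCC(=O)Nc1cc(OC)ccc1C(=O)c1ccc(OC)c2c1C=CC(C)(C)O2` gives 2310 nM

Going by the values given here, compound 2 lies within the scatter of compound 1, the only other measured compound, so the pair gives no ranking. Compound 3 `COc1ccc(C(=O)c2ccc(OC)c3c2C=CC(C)(C)O3)c(NC(=O)CN(C)C)c1` has the same atoms as compound 2, joined differently, with dimethylamino in place of ethylamino on a saturated chain carbon bound to a carbonyl carbon. Among the compounds with values here, the only measured change in this side chain is a 1.7-fold higher number from compound 1 to compound 2 (0.23 log units; within the scatter) and consists of methyl in place of hydrogen on a saturated chain carbon bound to an amine nitrogen. Within the data shown here, no measured compound carries dimethylamino, so the change itself is untested. Among the measured compounds shown here, with only that one small step as a guide, no step beyond the scatter is expected in this assay for this change, and no direction is favoured with any confidence. The estimate amounts to an expected 1.2-fold lower number from compound 2 to compound 3 (0.06 log units; within the scatter) and nothing more. Compound 3 is expected near 2000 nM (estimated range 900 nM to 4500 nM).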

Compound 3, half-maximal inhibitory concentration: 1850 nM
Compound 3: middle estimate off by 1.1-fold (0.03 log units), on the high side, and the stated range covers the measured number.
By their numbers in this assay, from the lowest: compounds 1, 3 and 2 (each within the scatter of the next).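

In this assay, dimethylamino in place of ethylamino on a saturated chain carbon bound to a carbonyl carbon gives a 1.2-fold lower number from compound 2 to compound 3 (0.10 log units; within the scatter), so this rearrangement of the same atoms does not separate the two compounds, even though the hydrogen-bond donor counted on ethylamino is absent from dimethylamino. Methyl in place of hydrogen on the amine nitrogen of compound 1 likewise gives only a 1.4-fold higher number from compound 1 to compound 3 (0.13 log units; within the scatter), which means that both extensions of that amine shown here, to ethylamino and to dimethylamino, stay within the scatter and the three compounds form no ranking at this position. Nothing available here accounts for these numbers.

As far as these compounds go, whether a ring amine such as pyrrolidine or morpholine, an unsubstituted amine, or a longer chain between the carbonyl and the amine would shift the number in this assay beyond the scatter remains open. The compounds shown cover only small changes on the amine nitrogen, so how much change this side chain tolerates is still unknown.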